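The compounds below may be only part of what the source reports. "The series", "measured", "known", "first", "only" and "open" are said of these compounds alone.

Measured compounds:
compound 1, `O=C(/C(=C\c1ccc(F)c([N+](=O)[O-])c1)S(=O)(=O)c1ccc(Br)cc1)c1ccc(Br)cc1`, 25000 nM
compound 2, `Cc1ccsc1/C=C(/SCc1ccc(Cl)cc1)C(=O)c1ccc(Cl)cc1`, 50000 nM

Of the compounds shown here, two have been tested in a functional assay on DU-145 cells (Homo sapiens) for inhibition, read by trypan blue exclusion, with a stated time of 96 h; a higher number here means a weaker inhibitor of growth, a lower number a stronger inhibitor of growth. Compound 1 gives 25000 nM, and compound 2 gives 50000 nM. The gap between these two numbers lies within the usual scatter of repeated measurements, so compound 1 and compound 2 stand together as weak inhibitors of growth, and neither can be called the stronger of the pair on this evidence.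

Compound 3, `COc1cccc(OC)c1/C=C(\C(=O)c1ccc(Br)cc1)S(=O)(=O)c1ccc(Br)cc1`, has not yet been measured. It shares its core with compound 1 and differs from it in one place: 2,6-dimethoxyphenyl in place of 4-fluoro-3-nitrophenyl on a double-bonded chain carbon bound to a double-bonded chain carbon. Going by the values given here, no measured pair in this set shows what such a change does in this assay, so nothing is known here about the size or direction of its effect. The only anchors are the two weak values already seen, both of the same order.

On that basis, compound 3 is expected to remain a weak inhibitor of growth, with an estimated step of a 1.2-fold higher number from compound 1 to compound 3 (0.08 log units; within the scatter) that does not reach beyond the scatter. The estimate for compound 3 in this assay is 30000 nM, within a range from 8000 nM to 100000 nM.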

Compound 3, concentration for 50% growth inhibition: 10000 nM
Estimate against measurement, compound 3: 3.0-fold (0.48 log units) above; low and high end bracket the measured number.
By their numbers in this assay, from the lowest: compound 3; then compounds 1 and 2 (each within the scatter of the next).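

Going by these compounds alone, this gives the first readable step at this position: in this assay, 2,6-dimethoxyphenyl in place of 4-fluoro-3-nitrophenyl on a double-bonded chain carbon bound to a double-bonded chain carbon gives a 2.5-fold lower number from compound 1 to compound 3 (0.40 log units; beyond the scatter) and so moves the result toward the stronger inhibitor of growth. The step is modest, and compound 3 at 10000 nM still lies far from a strong inhibitor, but it shows that the group at this place can change the reading while the rest of the core of compound 1 stays the same. The two groups count the same heavy atoms and hydrogen-bond acceptors, so those counts do not separate them, and nothing measured here says why the number moves.

Within the data shown here, with only this one step, it stays open whether the shift belongs to the arriving methoxy groups or to the departing nitro and fluoro groups. On these data alone, it is also open how a single methoxy group, an amine or a carboxylic acid at this place would read in this assay and whether any of them would carry the change further.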